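Aryl variation at the core of a sulfonamide series

The source may report more compounds than this note shows. Statements on the series, on what has been measured and on what is new or still open speak of the compounds shown alone.

Measured so far in a functional assay on MKN-45 cells (Homo sapiens) for inhibition, with a stated time of 72 h; a higher number here means a weaker inhibitor, a lower number a stronger inhibitor:
compound 1 `COc1ccc(S(=O)(=O)N2CCc3cccc(-c4ccc([N+](=O)[O-])cc4)c32)cc1` gives 34 nM;
compound 2 `COc1ccc(S(=O)(=O)N2CCc3cccc(-c4cccnc4)c32)cc1` gives 68.5 nM;
compound 3 `COc1ccc(S(=O)(=O)N2CCc3cccc(-c4ccc(O)cc4)c32)cc1` gives 82.6 nM.

Compound 3 carries the highest of the three numbers in this assay, separated from compound 1 by a 2.4-fold higher number from compound 1 to compound 3 (0.39 log units; beyond the scatter) but from compound 2 only by a 1.2-fold higher number from compound 2 to compound 3 (0.08 log units; within the scatter), so it cannot be ranked against compound 2.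

Compound 4 `COc1ccc(S(=O)(=O)N2CCc3cccc(-c4ccc(F)c(F)c4)c32)cc1` differs from compound 3 as follows: 3,4-difluorophenyl in place of 4-hydroxyphenyl on an aromatic carbon. The step bearing most directly on this is a 2.4-fold higher number from compound 1 to compound 3 (0.39 log units; beyond the scatter), which shows that removing the hydroxy in favour of another substituent can lower the number modestly; a 2.0-fold higher number from compound 1 to compound 2 (0.30 log units; within the scatter) and a 1.2-fold higher number from compound 2 to compound 3 (0.08 log units; within the scatter) stayed within the scatter. A modest fall is therefore expected for compound 4, roughly a 1.8-fold lower number from compound 3 to compound 4 (0.26 log units; within the scatter), with the estimate for compound 4 at 45 nM (range 20 nM to 110 nM).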

Compound 4, half-maximal inhibitory concentration: 55.5 nM
Compound 4: middle estimate off by 1.2-fold (0.09 log units), on the low side; the measured number falls inside the stated range.
By their numbers in this assay, from the lowest: compounds 1, 4, 2 and 3 (each within the scatter of the next, the first and the last beyond it).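

In this assay the swap to 3,4-difluorophenyl, which has no hydrogen-bond donor or acceptor, stays within the scatter of 4-hydroxyphenyl (a 1.5-fold lower number from compound 3 to compound 4 (0.17 log units; within the scatter)) and of pyridin-3-yl (a 1.2-fold lower number from compound 2 to compound 4 (0.09 log units; within the scatter)). It also stays within the scatter of 4-nitrophenyl (a 1.6-fold higher number from compound 1 to compound 4 (0.21 log units; within the scatter)), a gap that compound 3 exceeds, so this position tolerates an aryl group without the donor and acceptor of 4-hydroxyphenyl. No supporting data explain these steps.

Still open, as far as these compounds go, is whether an amine or a carboxylic acid on this aryl group would move the number beyond the scatter. Also open, from the compounds shown here alone, is whether a saturated ring such as morpholine could replace the aryl group.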